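A few compounds are considered here, and "the series" means these few. Any claim that something is new, unique, unknown or untested is made for them only; others in the source may bear on it.

Measured so far:
- compound 1, `CN(C)C(=O)c1cc2cnc(Nc3ccc(C(=O)NCCCCCN=C=S)cc3)nc2n1C1CCCC1`, 100%
- compound 2, `CN(C)C(=O)c1cc2cnc(Nc3ccc(C(=O)NCCCCCCN=C=S)cc3)nc2n1C1CCCC1`, where compound 1 gives 100%, compound 2 gives 100%
- compound 3, `CN(C)C(=O)c1cc2cnc(Nc3ccc(C(=O)NCCCN=C=S)cc3O)nc2n1C1CCCC1`, 73%

In a functional assay on A549 cells (Homo sapiens) for inhibition, read by CCK-8 assay, with a stated time of 72 h, tested at 10 uM (on this read-out lower numbers stand for a weaker effect and higher numbers for a stronger effect at the one concentration tested), compound 1 gives 100% and compound 2 gives 100%. The change from compound 1 to compound 2 is a group of 4 heavy atoms (2 carbon, 1 nitrogen, 1 sulfur; no ring) in place of a group of 3 heavy atoms (1 carbon, 1 nitrogen, 1 sulfur; no ring), on a saturated chain carbon, five bonds along the chain from an amide-type nitrogen, and the step it made is no change at the digits printed from compound 1 to compound 2 (within the scatter). Compound 3 gives 73% in this assay, the lowest of the three, beyond the usual scatter from both compound 1 and compound 2. The difference between the core of compound 3 and the core of compound 1 is not broken down here.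

Compound 4, `CN(C)C(=O)c1cc2cnc(Nc3ccc(C(=O)NCCCCN=C=S)cc3O)nc2n1C1CCCC1`, has not yet been measured. Relative to compound 3 it carries a group of 4 heavy atoms (2 carbon, 1 nitrogen, 1 sulfur; no ring) in place of a group of 3 heavy atoms (1 carbon, 1 nitrogen, 1 sulfur; no ring), on a saturated chain carbon, three bonds along the chain from an amide-type nitrogen. Among the measured compounds shown here, this is the same kind of change as the one from compound 1 to compound 2, but the place differs: there the group sits five bonds along the chain from the amide-type nitrogen, here three bonds along the chain. Because no change at the digits printed from compound 1 to compound 2 (within the scatter) was within the scatter, the expected step for compound 4 is small as well, a number 2 percentage points higher from compound 3 to compound 4 (within the scatter). Compound 4 is therefore estimated at 75% in this assay, expected to lie between 55% and 93%.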

Compound 4, a percentage reported as inhibition, at one concentration (the size of the read-out at that concentration, not a potency): 41.7%
The estimate for compound 4 lay 33.3 percentage points above the measured number, outside the stated range (below it).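

In this assay, putting a group of 4 heavy atoms in place of a group of 3 heavy atoms on the chain of compound 3 gave a number 31.3 percentage points lower from compound 3 to compound 4 (beyond the scatter). A flat result for this change on one core therefore cannot be assumed to hold on another core in this series: the same change on two cores in this assay, no change at the digits printed (within the scatter) from compound 1 to compound 2 and a number 31.3 percentage points lower (beyond the scatter) from compound 3 to compound 4, 31.3 percentage points apart, beyond the scatter of two such steps

The reason for the gap remains unknown: the two steps differ both in the core and in the place, five bonds along the chain from the amide-type nitrogen in one and three bonds along in the other, and one pair on each core cannot separate these two differences. The compounds shown leave open how a longer chain would behave on the core of compound 3, and whether the same change three bonds along the chain on the core of compound 1 would give a large step. They also leave open what an amine would give in place of the group of carbon, nitrogen and sulfur.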